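Swapping the benzylic aryl group in an HMG-CoA reductase inhibitor series

This account rests on a few compounds, and the source may have more. Where it says the series, first, only, none or still open, it means among the compounds named here.

Compound 1 `O=C(O)C[C@H](O)C[C@H](O)CCn1c(-c2ccc(F)cc2)nc(C(=O)NCc2ccc(F)c(F)c2)c1C1CC1`: 1.2 nM
Compound 2 `COc1ccc(CNC(=O)c2nc(-c3ccc(F)cc3)n(CC[C@@H](O)C[C@@H](O)CC(=O)O)c2C2CC2)cc1`: 1.2 nM
Compound 3 `Cc1cccc(CNC(=O)c2nc(-c3ccc(F)cc3)n(CC[C@@H](O)C[C@@H](O)CC(=O)O)c2C2CC2)c1`: 7.2 nM

In an assay on microsomes from liver for inhibition of 3-hydroxy-3-methylglutaryl-coenzyme A reductase (Rattus norvegicus), read by scintillation counting, with stated times of 0.5 h and 0.75 h (on this read-out lower numbers stand for stronger inhibition and higher numbers for weaker inhibition), compound 3 gives 7.2 nM, the highest of the three numbers. Compound 1 and compound 2 show no change at the digits printed between them, so the 3,4-difluorophenyl and 4-methoxyphenyl groups behave alike here; compound 3 differs only by a 3-methylphenyl group and a 6.0-fold higher number from compound 1 to compound 3 (0.78 log units; beyond the scatter) and a 6.0-fold higher number from compound 2 to compound 3 (0.78 log units; beyond the scatter) record the cost.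

Compound 4 `CN(C)S(=O)(=O)c1ccc(CNC(=O)c2nc(-c3ccc(F)cc3)n(CC[C@@H](O)C[C@@H](O)CC(=O)O)c2C2CC2)cc1` carries 4-(dimethylsulfamoyl)phenyl in place of 3-methylphenyl on a saturated chain carbon bound to an amide-type nitrogen. Among the compounds with values here, no measured step involves this group, but both measured swaps away from 3-methylphenyl gave lower numbers. A modest decrease is therefore expected, a 2.9-fold lower number from compound 3 to compound 4 (0.46 log units; beyond the scatter), and compound 4 is estimated at 2.5 nM, with a range from 0.8 nM to 8 nM.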

Compound 4, half-maximal inhibitory concentration in the 3-hydroxy-3-methylglutaryl-coenzyme A reductase assay: 4.9 nM
Estimate against measurement, compound 4: 2.0-fold (0.29 log units) below; the measured number falls inside the stated range.
By their numbers in the 3-hydroxy-3-methylglutaryl-coenzyme A reductase assay, from the lowest: compounds 1 and 2 (each within the scatter of the next); then compounds 4 and 3 (each within the scatter of the next).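

In the 3-hydroxy-3-methylglutaryl-coenzyme A reductase assay the larger 4-(dimethylsulfamoyl)phenyl group, with its hydrogen-bond acceptors, stands level with 3-methylphenyl (a 1.5-fold lower number from compound 3 to compound 4 (0.17 log units; within the scatter)), yet it does not match the other two groups (a 4.1-fold higher number from compound 2 to compound 4 (0.61 log units; beyond the scatter); a 4.1-fold higher number from compound 1 to compound 4 (0.61 log units; beyond the scatter)). In a physicochemical assay for lipophilicity, using the shake flask method, at pH 7.4 (on this read-out lower numbers stand for lower lipophilicity and higher numbers for higher lipophilicity), compound 3 gives 0.47 and compound 4 gives -0.46. The same change brings lipophilicity down, so this position can carry a less lipophilic group with no loss against compound 3: the measured distribution coefficient of compound 3, 0.47, and of compound 4, -0.46, a number 0.93 log units lower (beyond the scatter)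

Still open, on these data alone, is whether an amine or a carboxylic acid on this phenyl ring would keep the number in the 3-hydroxy-3-methylglutaryl-coenzyme A reductase assay as low as that of compound 1 (1.2 nM), and what such a group would do to the distribution coefficient.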